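The source may hold more compounds than are shown below. What is called first, only, known or untested is meant among the compounds shown, and "the series" means these compounds.

Measured compounds in a functional assay on SK-MEL-5 cells (Homo sapiens) for inhibition, read by sulforhodamine B assay, with a stated time of 48 h, tested at 10 uM; a higher number here means more inhibition at the concentration tested (going by the name of the read-out), a lower number less inhibition:
- compound 1 `c1ccc(-c2cn3ccnc3c(-c3ccc4ncn(C5CCCCC5)c4c3)n2)cc1` gives 36.5%
- compound 2 `COc1ccc(-c2cn3ccnc3c(-c3ccc4ncn(C5CCCCC5)c4c3)n2)cc1` gives 92.3%
- compound 3 `c1csc(-c2cn3ccnc3c(-c3ccc4ncn(C5CCCCC5)c4c3)n2)c1` gives 8.05%

Compound 3 stands lowest of the three measured numbers in this assay; its nearest neighbour is compound 1, and compound 2 lies furthest above it. The unmeasured compound 4 `FC(F)(F)c1cccc(-c2cn3ccnc3c(-c3ccc4ncn(C5CCCCC5)c4c3)n2)c1` differs from compound 3 in one place: 3-(trifluoromethyl)phenyl in place of thiophen-2-yl on an aromatic carbon. The step that bears most on this change is a number 28.5 percentage points lower from compound 1 to compound 3 (beyond the scatter), since compound 4 returns to a six-membered carbon ring on the same aromatic carbon where compound 3 carries a thiophen-2-yl, so the reverse of that step, a modest rise, is the natural starting point. Going by the values given here, the step of a number 55.8 percentage points higher from compound 1 to compound 2 (beyond the scatter) shows that a substituent on that ring can move the number a great deal, but no measured compound carries a trifluoromethyl, so the size of that effect here is unknown. A modest rise beyond the scatter is therefore expected, a number 32 percentage points higher from compound 3 to compound 4 (beyond the scatter). For compound 4 the estimate in this assay is 40%, with a range from 12% to 75%.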

Compound 4, a percentage reported as inhibition, at one concentration (the size of the read-out at that concentration, not a potency): 4.32%
Compound 4: the middle estimate sits 35.7 percentage points above what was measured; the measured number lies below the stated range.
By their numbers in this assay, from the lowest: compounds 4 and 3 (each within the scatter of the next); then compound 1; then compound 2.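

In this assay, a substituent on the phenyl ring can push the number down as well as up: trifluoromethyl in place of hydrogen gives a number 32.2 percentage points lower from compound 1 to compound 4 (beyond the scatter), against a number 55.8 percentage points higher from compound 1 to compound 2 (beyond the scatter) for methoxy. The two substituted rings stand far apart, with 3-(trifluoromethyl)phenyl in place of 4-methoxyphenyl giving a number 88 percentage points lower from compound 2 to compound 4 (beyond the scatter), so a six-membered carbon ring at this position does not by itself secure a high number. Placing 3-(trifluoromethyl)phenyl where thiophen-2-yl stood gives a number 3.7 percentage points lower from compound 3 to compound 4 (within the scatter), so this assay does not separate these two groups.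

Nothing measured here offers a reason for these differences. As far as these compounds go, it stays open whether the outcome follows from the group itself or from where it sits on the ring, and what an amine or a carboxylic acid on that ring would do.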